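A few compounds are considered here, and "the series" means these few. Any claim that something is new, unique, unknown or untested is made for them only; others in the source may bear on it.

In a functional assay on CHO cells for antagonist activity at adenosine receptor A2b (Homo sapiens), read by cAMP accumulation (on this read-out higher numbers stand for weaker inhibition and lower numbers for stronger inhibition), two compounds have been measured so far, and neither gives a number. Compound 1, `CCOc1cccc2cc(-c3ccc(OC)c(OC)c3)c(=O)oc12`, returns only a limit in this assay, > 30000 nM. Compound 2, `CCOc1cccc2cc(-c3cc(OC)c(OC)c(OC)c3)c(=O)oc12`, likewise returns only a limit in this assay, > 30000 nM. The step that the two limits leave unreadable from compound 1 to compound 2 therefore cannot be read; what the data show is that both values sit at the limit of > 30000 nM in this assay, at which 2 of the 2 values shown sit. This is where compound 2 stands: at the limit, with no number of its own.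

Compound 3, `COc1cc(-c2cc3cccc(C)c3oc2=O)cc(OC)c1OC`, differs from compound 2 at the core, by methyl in place of ethoxy on an aromatic carbon. Among the compounds with values here, no measured step bears directly on this change. Within the data shown here, the only step recorded, from compound 1 to compound 2, concerns a methoxy group on a different ring and is itself unreadable, so it gives no size and no direction to carry over.

With compound 2 standing only at a limit, the estimated step of a number no higher from compound 2 to compound 3 (the limit leaves the size open) is taken as no change beyond the scatter. Compound 3 is thus expected to give about 30000 nM in this assay, in a range from 8000 nM to 100000 nM, and most likely again as a limit rather than a number.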

Compound 3, half-maximal inhibitory concentration: > 30000 nM
Compound 3 gave a limit, no number (the forecaster's own chance of this, stated with the estimate: 75%); the middle value lies on the limit itself.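

In this assay compound 3 gives > 30000 nM as a limit and not a number, so the steps from compound 1 through compound 2 to compound 3 cannot be read. The compounds shown leave open how strongly any of them inhibits and whether methyl or ethoxy at this place makes any difference, since all sit at one limit: the limit of > 30000 nM in this assay, at which 3 of the 3 values shown sit.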